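The source may report more compounds than this note shows. Statements on the series, on what has been measured and on what is new or still open speak of the compounds shown alone.

The measured compounds, in a functional assay on HCT-116 cells (Homo sapiens) for inhibition; on this read-out lower numbers stand for stronger inhibition and higher numbers for weaker inhibition:
compound 1 `CCNC(=O)c1noc(-c2cc(C(C)C)c(O)cc2O)c1-c1cc(COCC(=O)OC)no1` gives 262 nM
compound 2 `CCNC(=O)c1noc(-c2cc(C(C)C)c(O)cc2O)c1-c1cc(COCC(N)=O)no1` gives 97 nM
compound 3 `CCNC(=O)c1noc(-c2cc(C(C)C)c(O)cc2O)c1-c1cc(CNC(C)C)no1` gives 109 nM

Compound 2 has the lowest number of the three, but its gap to compound 3, a 1.1-fold higher number from compound 2 to compound 3 (0.05 log units; within the scatter), lies within the scatter, so these two cannot be set in order. Only compound 1 stands apart: the steps of a 2.7-fold lower number from compound 1 to compound 2 (0.43 log units; beyond the scatter) and a 2.4-fold lower number from compound 1 to compound 3 (0.38 log units; beyond the scatter) are both beyond the scatter and both modest.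

Compound 4 `CCNC(=O)c1noc(-c2cc(C(C)C)c(O)cc2O)c1-c1cc(CNC(=O)CC)no1` has not been measured. It departs from compound 2 by propanoylamino in place of carbamoylmethoxy on a saturated chain carbon bound to an aromatic carbon. Going by the values given here, two measured steps bear on this change. The step of a 1.1-fold higher number from compound 2 to compound 3 (0.05 log units; within the scatter) swapped the same carbamoylmethoxy group at the same place for isopropylamino and left the number where it was. The step of a 2.7-fold lower number from compound 1 to compound 2 (0.43 log units; beyond the scatter) put amino in place of methoxy on a carbonyl carbon and lowered the number modestly, showing that the far end of this chain can matter somewhat, though that exchange is not the one made here. Taken together, no step beyond the scatter is expected in this assay, in either direction. Compound 4 is therefore estimated at 110 nM, with a range from 50 nM to 250 nM. The expected step from compound 2 is a 1.1-fold higher number from compound 2 to compound 4 (0.05 log units; within the scatter).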

Compound 4, half-maximal inhibitory concentration: 78 nM
For compound 4 the middle estimate is 1.4-fold (0.15 log units) above the measured one; the measured number falls inside the stated range.
By their numbers in this assay, from the lowest: compounds 4, 2 and 3 (each within the scatter of the next); then compound 1.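

In this assay, the new result shows that this place, a saturated chain carbon bound to an aromatic carbon, also accepts propanoylamino: exchanging carbamoylmethoxy for it gives a 1.2-fold lower number from compound 2 to compound 4 (0.09 log units; within the scatter). It also shows that the amine nitrogen can carry an acyl group as well as an alkyl group without a readable shift, since propanoyl in place of isopropyl gives a 1.4-fold lower number from compound 3 to compound 4 (0.15 log units; within the scatter). The (methoxycarbonyl)methoxy group remains the only one of the four that stands apart, now with a 3.4-fold lower number from compound 1 to compound 4 (0.53 log units; beyond the scatter), while the other three groups cannot be set in order, and nothing available here explains this difference.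

The compounds shown leave open whether a primary amine, a carboxylic acid or a longer chain such as butanoylamino at this place would stay level with these three groups or move the number beyond the scatter. They also leave open whether a ring on that nitrogen, such as morpholine, would be accepted as readily as the open chains seen so far.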